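From Phenyl to Bromo in a Cytotoxicity Test

The compounds below may be only part of what the source reports. "The series", "measured", "known", "first", "only" and "open" are said of these compounds alone.

Compound 1 `CCCNC(=O)C1CC12CCN(C(=O)c1cc3sc(-c4ccccc4)nc3n1Cc1ccc(OC)cc1)CC2` was examined in an ADME assay on HEK-293T cells (Homo sapiens) for cytotoxicity, read by luminescence and CellTiter-Glo, with a stated time of 24 h (on this read-out lower numbers stand for higher toxicity in this test and higher numbers for lower toxicity in this test), where compound 1 gives > 100000 nM. That entry is a limit of the assay and not a number, so compound 1 offers no exact starting point. Compound 2 `CCCNC(=O)[C@@H]1C[C@H]2CCC[C@@H](C1)[C@@H]2NC(=O)c1cc2scnc2n1Cc1ccc(OC)cc1` also returns only a limit, > 25000 nM. Compound 3 `CCCNC(=O)C1CCN(C(=O)c2cc3occc3n2Cc2ccc(OC)cc2)CC1` is the only one of the three with a number, and in this assay compound 3 gives 37200 nM.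

The next compound to be measured is compound 4 `CCCNC(=O)C1CC12CCN(C(=O)c1cc3sc(Br)nc3n1Cc1ccc(OC)cc1)CC2`. It departs from compound 1 at a single place: bromo in place of phenyl on an aromatic carbon. Among the compounds with values here, no two measured compounds differ in one place only, so no measured step bears directly on this change.

Within the data shown here, for compound 4 a modest move toward lower numbers in this assay is expected, an expectation that rests on compound 3 at 37200 nM, the one number available. The expected step of an at least 1.6-fold lower number from compound 1 to compound 4 (0.22 log units; that floor lies within the scatter) is only an estimate, and the assay may again return just a limit. For compound 4 the estimated value is 60000 nM, with an expected range of 25000 nM to 100000 nM.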

Compound 4, half-maximal cytotoxic concentration: 81300 nM
Estimate against measurement, compound 4: 1.4-fold (0.13 log units) below; the measured number falls inside the stated range.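

In this assay, within the data shown here, placing bromo in place of phenyl on the aromatic carbon next to the ring nitrogen and next to the ring sulfur gives an at least 1.2-fold lower number from compound 1 to compound 4 (0.08 log units; that floor lies within the scatter), the first step that can be read at this position, as none of the earlier compounds differed from another in one place only. Compound 4 gives 81300 nM, an exact number, so this position now carries a measured value, and it comes from a single bromine atom standing where a six-membered aromatic ring of carbon stood in compound 1. The value of compound 1 is a limit of the assay and not a number, so the step is only a floor and its true size stays unknown: the limit of > 100000 nM in this assay, at which 1 of the 4 values shown sits.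

The compounds shown leave open how an amine, a methoxy group or chloro on this same aromatic carbon would read in this assay, since bromo is the only replacement for phenyl here. They also leave open whether bromo in place of phenyl would give a similar step on the core of compound 2.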